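Aryl swap on the benzyl arm of the biaryl acid series

The source may report more compounds than this note shows. Statements on the series, on what has been measured and on what is new or still open speak of the compounds shown alone.

Measured so far:
compound 1 `O=C(O)c1ccccc1-c1ccc(CCc2ncc(Cc3ccccc3F)[nH]2)cc1` — 9.5 nM
compound 2 `CCCCc1cnc(C(CCCO)Cc2ccc(-c3ccccc3C(=O)O)cc2)[nH]1` — 238 nM

Going by the values given here, in an in vitro functional assay on cells for agonist activity at Bombesin receptor subtype-3 (Mus musculus), read by luminescence and calcium flux (on this read-out higher numbers stand for an effect only at larger amounts of compound and lower numbers for an effect already at smaller amounts), compound 1 gives 9.5 nM, the lowest of the two numbers known. Compound 2 gives 238 nM, a higher number that lies beyond the scatter. Compound 2 differs from compound 1 at several places at once, so no single step can be read between them; the two values only show that compound 1 is the better of the pair on this read-out.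

Compound 3 `Cc1ccc(Cc2cnc(CCc3ccc(-c4ccccc4C(=O)O)cc3)[nH]2)cc1` is the unmeasured follow-up to compound 1. It differs by 4-methylphenyl in place of 2-fluorophenyl on a saturated chain carbon bound to an aromatic carbon. Among the compounds with values here, nothing measured so far isolates this change, so the expectation rests on compound 1 alone. Compound 3 is expected to show a step of a 2.1-fold higher number from compound 1 to compound 3 (0.32 log units; beyond the scatter) from compound 1, small and likely within the scatter, in the direction of a somewhat higher number. Compound 3 is estimated at 20 nM, within 5 nM to 80 nM.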

Compound 3, half-maximal effective concentration: 162 nM
Estimate against measurement, compound 3: 8.1-fold (0.91 log units) below, and the stated range ends below it.
By their numbers in this assay, from the lowest: compound 1; then compounds 3 and 2 (each within the scatter of the next).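

In this assay, this position on the benzyl arm is far from indifferent to the aryl group: 4-methylphenyl in place of 2-fluorophenyl on a saturated chain carbon bound to an aromatic carbon gives a 17-fold higher number from compound 1 to compound 3 (1.23 log units; beyond the scatter), a large step. Both groups are a six-membered aromatic ring of carbon only, with no hydrogen-bond donors or acceptors and no net charge, so these shared features alone do not settle the read-out here. No measurement on hand accounts for the size of this step.

The swap removes a fluorine and adds a methyl in one change, so the compounds shown do not tell which of the two carries the step. An unsubstituted phenyl on the same carbon would be the direct test, as it would separate the loss of the fluorine from the gain of the methyl.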